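The source may report more compounds than this note shows. Statements on the series, on what has been measured and on what is new or still open speak of the compounds shown alone.

Compound 1 `N#Cc1c(N)sc(C(=O)Nc2ccccc2)c1-c1ccccc1` is the starting point of this step. In a functional assay on A549 cells (Homo sapiens) for inhibition, read by MTT assay (on this read-out higher numbers stand for weaker inhibition and lower numbers for stronger inhibition), compound 1 gives 8280 nM, and compound 2 `N#CCC(=O)Nc1sc(C(=O)Nc2ccccc2)c(-c2ccccc2)c1C#N` gives 7590 nM; the two sit within the scatter of each other, since a 1.1-fold lower number from compound 1 to compound 2 (0.04 log units; within the scatter). Compound 3 `N#Cc1c(N)sc(C(=O)Nc2ccc(Cl)cc2)c1-c1ccccc1` differs from compound 1 by chloro in place of hydrogen on an aromatic carbon. Among the measured compounds shown here, no measured step touches this part of the molecule, and the single step known, at the amine, stayed within the scatter. Compound 3 is therefore expected to stay close to compound 1, with a 1.3-fold lower number from compound 1 to compound 3 (0.11 log units; within the scatter), so an estimate of 6500 nM with a range from 2500 nM to 16000 nM.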

Compound 3, half-maximal inhibitory concentration: 700 nM
Compound 3: middle estimate off by 9.3-fold (0.97 log units), on the high side, outside the stated range (below it).
By their numbers in this assay, from the lowest: compound 3; then compounds 2 and 1 (each within the scatter of the next).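

In this assay, the anilino end of the molecule proves far more sensitive than the amine: going from phenyl to 4-chlorophenyl, a change of a single chlorine atom, gives a 12-fold lower number from compound 1 to compound 3 (1.07 log units; beyond the scatter), a large gain in inhibition, whereas the change at the amine stayed within the scatter. Nothing available explains why this one atom matters so much.

As far as these compounds go, whether fluoro, bromo, methoxy or a carboxylic acid at the same place would do the same stays open. So does whether chloro elsewhere on that ring would keep the gain.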